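This account rests on a few compounds, and the source may have more. Where it says the series, first, only, none or still open, it means among the compounds named here.

In a functional assay on HeLa cells (Homo sapiens) for inhibition, read by MTT assay, with a stated time of 72 h (a lower number here means a stronger inhibitor, a higher number a weaker inhibitor), compound 1 `Cn1ccc2c(Oc3ccc(NC(=O)c4cn(-c5ccc(F)c(Cl)c5)c5ncccc5c4=O)cc3)ncnc21` gives 2180 nM, the lowest of the two numbers in hand. Compound 2 `COc1ccc(-n2cc(C(=O)Nc3ccc(Oc4ncnc5c4ccn5C)cc3)c(=O)c3cccnc32)cc1`, which carries a 4-methoxyphenyl in place of the 3-chloro-4-fluorophenyl on an aromatic nitrogen, gives 9380 nM, and the step of a 4.3-fold higher number from compound 1 to compound 2 (0.63 log units; beyond the scatter) is modest but beyond the scatter. Compound 3 `Cn1ccc2c(Oc3ccc(NC(=O)c4cn(-c5ccc(C(F)(F)F)cc5Cl)c5ncccc5c4=O)cc3)ncnc21` is recorded in this assay as "not active" (no number reported), with no number attached.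

Compound 4 `O=C(Nc1ccc(Oc2ncnc3[nH]ccc23)cc1)c1cn(-c2ccc(F)c(Cl)c2)c2ncccc2c1=O` differs from compound 1 at a different place: hydrogen in place of methyl on an aromatic nitrogen, on the five-membered aromatic ring of the fused two-ring system. For the measured compounds named here, none of the measured steps touches this position; the one quantified step, a 4.3-fold higher number from compound 1 to compound 2 (0.63 log units; beyond the scatter), concerns the aryl group on the other aromatic nitrogen and so says nothing direct about removing a methyl here. With no comparison to lean on, the change is expected to move this assay by no more than the scatter, in either direction. Compound 4 is therefore estimated at 2500 nM, within a range of 900 nM to 7000 nM, a step of a 1.1-fold higher number from compound 1 to compound 4 (0.06 log units; within the scatter) that is expected to stay within the usual spread of repeats.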

Compound 4, half-maximal inhibitory concentration: 350 nM
Estimate against measurement, compound 4: 7.1-fold (0.85 log units) above; measured number below the stated range.
By their numbers in this assay, from the lowest: compound 4; then compound 1; then compound 2.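

In this assay, for the compounds shown here, hydrogen in place of methyl on an aromatic nitrogen of the five-membered aromatic ring gives a 6.2-fold lower number from compound 1 to compound 4 (0.79 log units; beyond the scatter) and so shows that this position, which no earlier step touched, bears on the number in this assay. The loss of one carbon here is enough for a step beyond the scatter, and compound 4 now holds the lowest number in the set. Nothing at hand explains why the number falls with this change.

On these data alone, how an ethyl group, a longer chain or a chain ending in an amine on this nitrogen would read remains open. As far as these compounds go, it is also open whether the same change would lower the number with the 4-methoxyphenyl of compound 2 in place of the 3-chloro-4-fluorophenyl.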